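Replacing the 1H-indol-3-yl group of compound 2

The source may report more compounds than this note shows. Statements on the series, on what has been measured and on what is new or still open speak of the compounds shown alone.

Values so far in a functional assay on DU-145 cells (Homo sapiens) for inhibition, read by trypan blue exclusion, with a stated time of 96 h; on this read-out lower numbers stand for stronger inhibition of growth and higher numbers for weaker inhibition of growth
- compound 1 (`O=C(O)c1ccc(/C=C(/SCc2ccc(Cl)cc2)C(=O)c2ccc(C(=O)O)cc2)cc1`) gives > 100000 nM which is a limit of the assay
- compound 2 (`Cc1ccc(S/C(=C/c2c[nH]c3ccccc23)C(=O)c2ccc(Br)cc2)cc1`) gives 10000 nM
- compound 3 (`O=C(/C(=C\c1ccc(O)c([N+](=O)[O-])c1)SCc1ccc(Cl)cc1)c1ccc(Cl)cc1`) gives 10000 nM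

Compound 2 stands level with compound 3 (10000 nM) at the digits shown, within the scatter. The only other figure, that of compound 1, is a limit of the assay. Compound 4 (`Cc1ccc(S/C(=C/c2ccc(F)c(C)c2)C(=O)c2ccc(Br)cc2)cc1`) differs from compound 2 in one place (4-fluoro-3-methylphenyl in place of 1H-indol-3-yl on a double-bonded chain carbon bound to a double-bonded chain carbon), with 4-fluoro-3-methylphenyl in place of 1H-indol-3-yl on a double-bonded chain carbon bound to a double-bonded chain carbon. Among the compounds with values here, no measured pair isolates such a change, so the expectation rests on compound 2 (10000 nM), and no step beyond the scatter is expected in this assay. The estimated change is small (a 1.3-fold lower number from compound 2 to compound 4 (0.10 log units; within the scatter)). Compound 4 is expected at 8000 nM (estimated range 1500 nM to 40000 nM).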

Compound 4, concentration for 50% growth inhibition: 25000 nM
Compound 4: the middle estimate sits 3.1-fold (0.49 log units) below what was measured; low and high end bracket the measured number.
By their numbers in this assay, from the lowest: compounds 2 and 3 (each within the scatter of the next); then compound 4. At a limit, above all of these: compound 1.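

In this assay, 4-fluoro-3-methylphenyl in place of 1H-indol-3-yl gives a 2.5-fold higher number from compound 2 to compound 4 (0.40 log units; beyond the scatter), which means weaker inhibition of growth. Within the data shown here, this is the first change in a single place that can be read, and it shows that the group on a double-bonded chain carbon bound to a double-bonded chain carbon affects the read-out, though modestly.

On these data alone, how a pyridyl group or an unsubstituted phenyl would read at this position remains open. The compounds shown also leave the cause of this step unexplained.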